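The source may report more compounds than this note shows. Statements on the series, on what has been measured and on what is new or still open speak of the compounds shown alone.

Two compounds measured in a functional assay on MCF7 cells (Homo sapiens) for antiproliferative activity, read by MTT assay, with a stated time of 48 h (on this read-out lower numbers stand for stronger inhibition and higher numbers for weaker inhibition), form the starting point. Compound 1 `O=C(Nc1cccc(/C=C/C(=O)c2nc3ccccc3[nH]2)c1)c1ccc(Cl)cc1` gives 8410 nM, and compound 2 `Cc1ccccc1C(=O)Nc1cccc(/C=C/C(=O)c2nc3ccccc3[nH]2)c1` gives 5870 nM. Compound 2 thus shows the lowest of the two numbers, yet the step of a 1.4-fold lower number from compound 1 to compound 2 (0.16 log units; within the scatter) lies within the scatter, so the two stand level. Compound 3 `Cc1cccc(C(=O)Nc2cccc(/C=C/C(=O)c3nc4ccccc4[nH]3)c2)c1` is the next compound. It differs from compound 2 in one place: 3-methylphenyl in place of 2-methylphenyl on a carbonyl carbon. Going by the values given here, only one measured step bears on this change, the one from compound 1 to compound 2, which also exchanged the group on that carbonyl carbon and moved the number by no more than the scatter allows. On that basis no step beyond the scatter in this assay is expected. The step from compound 2 to compound 3 is therefore estimated as a 1.1-fold lower number from compound 2 to compound 3 (0.03 log units; within the scatter). For compound 3 the expected value is 5500 nM, with a range from 2500 nM to 12000 nM.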

Compound 3, half-maximal inhibitory concentration: 5590 nM
For compound 3 the middle estimate is 1.0-fold (0.01 log units) below the measured one; low and high end bracket the measured number.
By their numbers in this assay, from the lowest: compounds 3, 2 and 1 (each within the scatter of the next).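

In this assay, 3-methylphenyl in place of 2-methylphenyl on the carbonyl carbon gives a 1.1-fold lower number from compound 2 to compound 3 (0.02 log units; within the scatter), so a change that joins the same atoms differently leaves the two compounds level. The step of a 1.5-fold lower number from compound 1 to compound 3 (0.18 log units; within the scatter) also stays within the scatter, which means that 4-chlorophenyl, 2-methylphenyl and 3-methylphenyl at this place cannot be told apart by these numbers. No evidence is at hand that could account for this.

The compounds shown leave open whether a different kind of group on this carbonyl carbon, such as a pyridyl ring, an aminophenyl or a carboxylic acid-bearing phenyl, would move the number beyond the scatter. They also leave open whether any change to the shared core, away from this carbonyl carbon, would do so.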